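The source may report more compounds than this note shows. Statements on the series, on what has been measured and on what is new or still open speak of the compounds shown alone.

For the measured compounds named here, compound 2 `CC(C)=CC[C@@H](OC(=O)CC(C)(O)C(C)C)C1=CC(=O)c2c(O)ccc(O)c2C1=O` is one of two compounds measured in a functional assay on DU-145 cells (Homo sapiens) for cytotoxicity, read by MTT assay; on this read-out higher numbers stand for weaker inhibition and lower numbers for stronger inhibition. In this assay compound 2 gives 16900 nM, the highest of the two numbers available. Going by the values given here, its only neighbour, compound 1 `CC(C)=CC[C@@H](OC[C@@H](C)O)C1=CC(=O)c2c(O)ccc(O)c2C1=O`, gives 14300 nM in this assay. The two differ in the group attached to an oxygen on a saturated carbon, and the step of a 1.2-fold higher number from compound 1 to compound 2 (0.07 log units; within the scatter) lies within the scatter of repeated measurements, so the two values cannot be told apart.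

Compound 3 `CC(C)=CC[C@@H](OC(=O)c1ccoc1)C1=CC(=O)c2c(O)ccc(O)c2C1=O`, not yet measured, differs from compound 2 at the same part of the shared core: furan-3-yl in place of 2-hydroxy-2,3-dimethylbutyl on a carbonyl carbon. Among the compounds with values here, this brings an aromatic ring into the side chain, and no measured step covers such a replacement. Within the data shown here, the one step that exists, a 1.2-fold higher number from compound 1 to compound 2 (0.07 log units; within the scatter), shows that reworking this side chain left the number within the scatter, which gives only weak guidance. For compound 3 the expected step is therefore a 1.1-fold lower number from compound 2 to compound 3 (0.05 log units; within the scatter), with nothing beyond the scatter foreseen. Compound 3 is estimated to give 15000 nM in this assay, within a likely range from 6000 nM to 40000 nM.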

Compound 3, half-maximal inhibitory concentration: > 100000 nM
Compound 3 was reported as a limit (the forecaster's own chance of this, stated with the estimate: 10%); middle value at least 6.6-fold (0.82 log units) away from the limit.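

The value for compound 3 is a limit of the assay rather than a number: the limit of > 100000 nM in this assay, at which 1 of the 3 values shown sits.

Even so, the change can be read: furan-3-yl in place of 2-hydroxy-2,3-dimethylbutyl on the carbonyl carbon gives an at least 5.9-fold higher number from compound 2 to compound 3 (0.77 log units; beyond the scatter), and (furan-3-yl)carbonyl in place of 2-hydroxypropyl on the oxygen on a saturated carbon gives an at least 6.9-fold higher number from compound 1 to compound 3 (0.84 log units; beyond the scatter). The earlier pair, with a 1.2-fold higher number from compound 1 to compound 2 (0.07 log units; within the scatter), made this side chain look tolerant of reworking, whereas these steps show that in this assay the group at this position can weaken inhibition well beyond the scatter, and among these three compounds only the one with an aromatic ring in this group does so.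

The change replaces an open chain carrying a hydrogen-bond donor with a ring that has none, so these compounds cannot separate the effect of adding the ring from that of losing the donor. They also leave open how a saturated ring such as tetrahydrofuran-3-yl, a phenyl ring, or a furan-3-yl carrying a hydroxymethyl group would read at this position.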